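Chloro added to the anilide ring of compound 3

A few compounds are considered here, and "the series" means these few. Any claim that something is new, unique, unknown or untested is made for them only; others in the source may bear on it.

Compound 1 `Cc1noc(C)c1-c1cnc(N)c(Oc2ccc(C(=O)Nc3ccccc3)cc2)n1`: 26600 nM
Compound 2 `Cc1noc(C)c1-c1cnc(N)c(Oc2ccc(C(=O)Nc3cc(Cl)ccn3)cc2)n1`: 70800 nM
Compound 3 `Cn1cc(-c2cnc(N)c(Oc3ccc(C(=O)Nc4ccccc4)cc3)n2)cn1`: 17700 nM

In a functional assay on U-87MG ATCC cells for inhibition, with U-87 MG (Homo sapiens) as the target, read by MTT assay, with a stated time of 72 h (a lower number here means a stronger inhibitor, a higher number a weaker inhibitor), compound 3 gives the lowest of the three numbers, but the gap to compound 1 is within the scatter, so only the distance to compound 2 counts as a real difference. Compound 4 `Cn1cc(-c2cnc(N)c(Oc3ccc(C(=O)Nc4ccc(Cl)cc4)cc3)n2)cn1` differs from compound 3 by chloro in place of hydrogen on an aromatic carbon; the chloro enters on an aromatic carbon of the six-membered carbon-only ring, para to a large group. Among the compounds with values here, no measured pair shows exactly this change. The nearest guide is a 2.7-fold higher number from compound 1 to compound 2 (0.43 log units; beyond the scatter), which swapped the whole ring on the amide nitrogen for a chlorine-bearing pyridine and gave a modest weakening. The other known step, a 1.5-fold lower number from compound 1 to compound 3 (0.18 log units; within the scatter), concerns a distant part of the molecule and says little here. A small shift, probably none beyond the scatter and if anything toward a higher number, is therefore expected, a 1.2-fold higher number from compound 3 to compound 4 (0.09 log units; within the scatter). Compound 4 is estimated at 22000 nM, with a likely range from 8000 nM to 60000 nM.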

Compound 4, half-maximal inhibitory concentration: 35800 nM
For compound 4 the middle estimate is 1.6-fold (0.21 log units) below the measured one; the measured number falls inside the stated range.
By their numbers in this assay, from the lowest: compounds 3, 1, 4 and 2 (each within the scatter of the next, the first and the last beyond it).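

In this assay, chloro in place of hydrogen on the six-membered carbon-only ring, para to a large group, gives a 2.0-fold higher number from compound 3 to compound 4 (0.31 log units; beyond the scatter) and so moves the number toward weaker inhibition by more than the usual scatter. The earlier chlorine-bearing compound 2 differed from compound 1 by a whole change of ring, whereas this pair changes phenyl to 4-chlorophenyl and nothing else, so the step can be tied to chloro at this one place. No supporting measurement is available to explain the rise.

The compounds shown leave open whether a fluoro or a methoxy group at this same carbon would give a similar step, or whether chloro at another carbon of the ring would. Going by these compounds, it is also open whether chloro would do the same with the 3,5-dimethyl-1,2-oxazol-4-yl group in place of the 1-methyl-1H-pyrazol-4-yl group.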